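Sulfone for Thioether on a Trifluoromethyl-Bearing Core

A few compounds are considered here, and "the series" means these few. Any claim that something is new, unique, unknown or untested is made for them only; others in the source may bear on it.

Compound 1, `COc1ccc(S(C)(=O)=O)c(NCC2=NCCN2)c1`: in an assay on CHO cells for binding affinity to Alpha-2B adrenergic receptor (Homo sapiens), read by radioligand binding (on this read-out lower numbers stand for stronger inhibition and higher numbers for weaker inhibition), compound 1 gives < 6310 nM, a limit of the assay rather than a number.
Compound 2, `Cc1ccc(S(C)(=O)=O)c(NCC2=NCCN2)c1`: in this assay compound 2 gives < 6310 nM, also a limit.
Compound 3, `CSc1ccc(C(F)(F)F)cc1NCC1=NCCN1`: in this assay compound 3 gives 1660 nM.

Going by the values given here, compound 3 thus holds the only measured number; the other two values are limits, and so the step that the two limits leave unreadable from compound 1 to compound 2 cannot be read in size. Compound 4, `CS(=O)(=O)c1ccc(C(F)(F)F)cc1NCC1=NCCN1`, differs from compound 3 by methylsulfonyl in place of methylsulfanyl on an aromatic carbon. Among the compounds with values here, no measured step runs through this exact change. Compounds 1 and 2 do carry the methylsulfonyl group, but both sit at the limit of < 6310 nM in this assay, at which 2 of the 3 values shown sit, which supplies no number to compare against. The step of a 1.2-fold higher number from compound 3 to compound 4 (0.08 log units; within the scatter) is therefore expected without a direct precedent, and any change beyond the scatter is uncertain in direction. Compound 4 is estimated at 2000 nM, between 500 nM and 8000 nM.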

Compound 4, inhibition constant: < 6310 nM
Compound 4 was reported as a limit (the forecaster's own chance of this, stated with the estimate: 25%); the middle value does not contradict the limit.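

In this assay, compound 4 gives a limit rather than a number, so its steps from compound 1, compound 2 and compound 3 cannot be read: the limit of < 6310 nM in this assay, at which 3 of the 4 values shown sit. From the compounds shown here alone, whether methylsulfonyl in place of methylsulfanyl changes the number at all stays open.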